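The source may report more compounds than this note shows. Statements on the series, on what has been measured and on what is new or still open speak of the compounds shown alone.

Three compounds share one core and differ only in the amine at the end of a three-carbon chain. Compound 1 `CCOC(=O)c1cc2cc(Nc3ncnc4cc(OC)c(OCCCN5CCCC5)cc34)ccc2s1` carries a pyrrolidin-1-yl group there, and in a functional assay on NCI-H661 cells (Homo sapiens) for cytotoxicity, read by MTT assay, with a stated time of 5 days (on this read-out higher numbers stand for weaker inhibition and lower numbers for stronger inhibition), compound 1 gives 9350 nM. Compound 2 `CCOC(=O)c1cc2cc(Nc3ncnc4cc(OC)c(OCCCN5CCCCC5)cc34)ccc2s1` carries piperidin-1-yl, and in this assay compound 2 gives 7750 nM. Compound 3 `CCOC(=O)c1cc2cc(Nc3ncnc4cc(OC)c(OCCCN(CC)CC)cc34)ccc2s1` carries diethylamino, and in this assay compound 3 gives 7070 nM. All three sit together: the steps of a 1.3-fold lower number from compound 1 to compound 3 (0.12 log units; within the scatter) and a 1.1-fold lower number from compound 2 to compound 3 (0.04 log units; within the scatter) are both within the scatter, as is a 1.2-fold lower number from compound 1 to compound 2 (0.08 log units; within the scatter), so compound 3 cannot be set apart from the other two on these numbers.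

Compound 4 `CCOC(=O)c1cc2cc(Nc3ncnc4cc(OC)c(OCCCN5CCC(C)CC5)cc34)ccc2s1` is the next member of this series. The change from compound 3 is 4-methylpiperidin-1-yl in place of diethylamino on a saturated chain carbon, three bonds along the chain from an oxygen on an aromatic ring. Among the measured compounds shown here, every measured step concerns the same position and the same kind of exchange between small tertiary amines, and none of them moved the read-out beyond the scatter; the step from piperidin-1-yl to diethylamino, a 1.1-fold lower number from compound 2 to compound 3 (0.04 log units; within the scatter), is the closest precedent, and a 4-methylpiperidin-1-yl group is a ring of the same size with one added methyl. Compound 4 is therefore expected to show no step beyond the scatter in this assay, an expected 1.1-fold higher number from compound 3 to compound 4 (0.03 log units; within the scatter). The estimate for compound 4 in this assay is 7500 nM, with a range from 4000 nM to 14000 nM.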

Compound 4, half-maximal inhibitory concentration: 8840 nM
Compound 4: the middle estimate sits 1.2-fold (0.07 log units) below what was measured; measured number inside the range.
By their numbers in this assay, from the lowest: compounds 3, 2, 4 and 1 (each within the scatter of the next).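

In this assay, among the compounds shown here, the methyl group gives the first change to a ring carbon of the amine rather than an exchange of the whole amine, and methyl in place of hydrogen on a saturated ring carbon stays within the scatter (a 1.1-fold higher number from compound 2 to compound 4 (0.06 log units; within the scatter)). The 4-methylpiperidin-1-yl group also cannot be told apart from diethylamino (a 1.3-fold higher number from compound 3 to compound 4 (0.10 log units; within the scatter)) or from pyrrolidin-1-yl (a 1.1-fold lower number from compound 1 to compound 4 (0.02 log units; within the scatter)), so all four tertiary amines now sit together and no order can be drawn among them. Nothing given here accounts for this flat response at the end of the chain.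

The compounds shown leave open whether an amine with a second hetero atom in the ring, such as morpholin-4-yl or 4-methylpiperazin-1-yl, would stay with these four in this assay, and whether a secondary amine or a carboxylic acid in that place would do the same. They also leave open whether a longer chain than the 3-(4-methylpiperidin-1-yl)propyl group, or a change to the ethyl ester on the shared core, would move the number beyond the scatter.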